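The compounds below may be only part of what the source reports. "The series", "measured", "known", "first", "only" and "open" are said of these compounds alone.

Compound 1 `O=C(Nc1nc2ccc(-c3cn([C@@H]4CN[C@H](C(=O)Nc5ccc(Cl)c(C(F)(F)F)c5)C4)nn3)nc2s1)C1CC1` gives 16200 nM 
Compound 2 `CC(=O)Nc1nc2ccc(-c3cn([C@@H]4CN[C@H](C(=O)Nc5ccc(Cl)cc5Cl)C4)nn3)nc2s1` gives 9670 nM 

In a functional assay on K562 cells (Homo sapiens) for inhibition, read by MTT assay, with a stated time of 48 h (on this read-out higher numbers stand for weaker inhibition and lower numbers for stronger inhibition), compound 2 reads 9670 nM and lies within the scatter of compound 1 (16200 nM), so neither of the two stands apart on these numbers. Compound 3 `O=C(Nc1nc2ccc(-c3cn([C@@H]4CN[C@H](C(=O)Nc5ccc(Cl)cc5Cl)C4)nn3)nc2s1)C1CC1` departs from compound 2 in one place, with cyclopropyl in place of methyl on a carbonyl carbon. Going by the values given here, no measured pair differs by this change alone, so the data give no direct size for it. In this assay no step beyond the scatter is expected, in either direction. The expectation rests on compound 2 at 9670 nM as the closest measured reference. The estimated change is a 1.1-fold higher number from compound 2 to compound 3 (0.06 log units; within the scatter) and would stay within the scatter. For compound 3 the estimated value is 11000 nM with an expected range from 4500 nM to 26000 nM in this read-out.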

Compound 3, half-maximal inhibitory concentration: 740 nM
For compound 3 the middle estimate is 15-fold (1.17 log units) above the measured one, and the stated range ends above it.
By their numbers in this assay, from the lowest: compound 3; then compounds 2 and 1 (each within the scatter of the next).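

In this assay the position on the carbonyl carbon turns out to matter: with the 2,4-dichlorophenyl group held in place, cyclopropyl in place of methyl gives a 13-fold lower number from compound 2 to compound 3 (1.12 log units; beyond the scatter) on its own. The group on the other amide-type nitrogen matters as well, since with the cyclopropylcarbonyl group held in place, 2,4-dichlorophenyl in place of 4-chloro-3-(trifluoromethyl)phenyl gives a 22-fold lower number from compound 1 to compound 3 (1.34 log units; beyond the scatter) in this one change, which the earlier pair, differing in two places, could not show. Nothing at hand explains either step.

On these data alone, whether the effect is particular to the three-membered ring stays open, as an ethyl, isopropyl or cyclobutyl group on the same carbonyl carbon would show. Also open, as far as these compounds go, is whether cyclopropyl in place of methyl gives a step of similar size alongside the 4-chloro-3-(trifluoromethyl)phenyl group.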